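This account rests on a few compounds, and the source may have more. Where it says the series, first, only, none or still open, it means among the compounds named here.

Measured compounds in this series:

compound 1, `O=C(CCC(=O)OCCCCCCSc1ccc([N+](=O)[O-])c2nonc12)Nc1ccccc1Cl` — 330 nM
compound 2, `O=C(CCC(=O)OCCCCCCSc1ccc([N+](=O)[O-])c2nonc12)Nc1cccc(Cl)c1` — 1100 nM
compound 3, `Cc1ccc(NC(=O)CCC(=O)OCCCCCCSc2ccc([N+](=O)[O-])c3nonc23)cc1` — 390 nM

In an assay on isolated protein for inhibition of glutathione S-transferase Mu 2 (Homo sapiens), with a stated time of 10 min (a lower number here means a stronger inhibitor, a higher number a weaker inhibitor), compound 1 gives the lowest of the three numbers. Its nearest neighbour is compound 3: a 1.2-fold higher number from compound 1 to compound 3 (0.07 log units; within the scatter), so the two cannot be ranked against each other. The furthest is compound 2: a 3.3-fold higher number from compound 1 to compound 2 (0.52 log units; beyond the scatter). Between the other pair, a 2.8-fold lower number from compound 2 to compound 3 (0.45 log units; beyond the scatter).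

Compound 4, `CN(C)CCNC(=O)CCC(=O)OCCCCCCSc1ccc([N+](=O)[O-])c2nonc12`, is not yet measured. It differs from compound 1 at the amide-type nitrogen: 2-(dimethylamino)ethyl in place of 2-chlorophenyl on an amide-type nitrogen. None of the three measured steps bears directly on this change. All three exchange one substituted phenyl ring for another at the same nitrogen, and the largest spread they show is a 3.3-fold higher number from compound 1 to compound 2 (0.52 log units; beyond the scatter). The move to 2-(dimethylamino)ethyl removes the aromatic ring altogether, which the measured set does not test, so the expectation rests only on the observation that all three aryl variants stay within a modest band.

For compound 4 the expected step is a 4.5-fold higher number from compound 1 to compound 4 (0.66 log units; beyond the scatter), an upward movement, with a wide range because the measured steps do not cover a change of this kind. The estimate for compound 4 is 1500 nM, between 400 nM and 6000 nM.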

Compound 4, half-maximal inhibitory concentration: 160 nM
The estimate for compound 4 lay 9.4-fold (0.97 log units) above the measured number; the whole stated range lies above it.
By their numbers in this assay, from the lowest: compound 4; then compounds 1 and 3 (each within the scatter of the next); then compound 2.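

In this assay the 2-(dimethylamino)ethyl group on the amide-type nitrogen gives the lowest number of the four compounds, with a 2.1-fold lower number from compound 1 to compound 4 (0.31 log units; beyond the scatter) and a 2.4-fold lower number from compound 3 to compound 4 (0.39 log units; beyond the scatter) as well as a 6.9-fold lower number from compound 2 to compound 4 (0.84 log units; beyond the scatter) in the same direction, all three modest in size. An aromatic ring on this nitrogen is therefore not needed for a number at or below those of compound 1 and compound 3, which the three substituted phenyl variants could not show because each of them carries that ring. The position accepts both substituted phenyl groups and this open chain, so what sits on the nitrogen can change from an aromatic ring to a chain ending in a tertiary amine with no loss in this assay.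

Still open, from the compounds shown here alone, is which part of the new group matters: a 2-methoxyethyl chain, a primary amine on the same ethyl chain, a longer 3-(dimethylamino)propyl chain or a carboxylic acid at the chain end would each separate the amine from the loss of the ring. Nothing available here gives a reason for the lower number of compound 4.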